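This account rests on a few compounds, and the source may have more. Where it says the series, first, only, none or still open, it means among the compounds named here.

Measured so far in an ADME assay on microsomes from liver (Rattus norvegicus) for metabolic stability, with a stated time of 10 min; on this read-out higher numbers stand for a more stable compound and lower numbers for a less stable compound:
compound 1 `O=C(NS(=O)(=O)c1ccccc1)c1ccc(Nc2nc(NC3(c4ccc(Cl)cc4)CC3)nc(OCC(F)(F)F)n2)cc1` — 100%
compound 2 `CNC(=O)NCCS(=O)(=O)NC(=O)c1ccc(Nc2nc(NC3(c4ccc(Cl)cc4)CC3)nc(OCC(F)(F)F)n2)cc1` — 100%

Compound 1 stands level with compound 2 at the digits shown; the only measured step, no change at the digits printed from compound 1 to compound 2 (within the scatter), alters the group on the sulfonyl sulfur, 2-((methylcarbamoyl)amino)ethyl in place of phenyl, and leaves the read-out unchanged.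

Compound 3 `CN(C)S(=O)(=O)NC(=O)c1ccc(Nc2nc(NC3(c4ccc(Cl)cc4)CC3)nc(OCC(F)(F)F)n2)cc1` is not yet measured. Against compound 1 it shows (dimethylamino in place of phenyl on a sulfonyl sulfur), that is phenylsulfonyl to dimethylsulfamoyl, the rest of the shared core untouched. The step bearing on it is that from compound 1 to compound 2, which changes the same position and was flat. For compound 3 the expected step is therefore a number 3 percentage points lower from compound 1 to compound 3 (within the scatter), none beyond the scatter. Compound 3 is estimated at 97%, with a range from 85% to 100%, resting on one flat step only.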

Compound 3, percent of the compound remaining: 76%
Compound 3: middle estimate off by 21 percentage points, on the high side; measured number outside the range, below it.
By their numbers in this assay, from the lowest: compound 3; then compounds 1 and 2 (each within the scatter of the next).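

In this assay, dimethylamino in place of phenyl on the sulfonyl sulfur gives a number 24 percentage points lower from compound 1 to compound 3 (beyond the scatter) and dimethylamino in place of 2-((methylcarbamoyl)amino)ethyl gives a number 24 percentage points lower from compound 2 to compound 3 (beyond the scatter). This position therefore does respond to the group placed on it, and the flat result of no change at the digits printed from compound 1 to compound 2 (within the scatter) holds for that pair of groups only, not for every change at this sulfur. No measured data are available to explain the lower number for compound 3.

The compounds shown leave open whether the lower number goes with a nitrogen attached to the sulfonyl sulfur or with the absence of a ring. A morpholine on that sulfur, which has the nitrogen and a ring, and a plain methyl, which has neither, would separate the two.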